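The compounds below may be only part of what the source reports. "The series", "measured", "known", "first", "only" and "open" are said of these compounds alone.

Measured compounds:
compound 1 `Cc1ccccc1-n1nc(C)c2c1NC(=O)[C@H](C)S[C@@H]2c1ccc(-c2ccccc2)cc1` — 990 nM
compound 2 `CCOc1cccc(-c2ccc([C@H]3S[C@@H](C)C(=O)Nc4c3c(C)nn4-c3ccccc3C)cc2)c1` — 3500 nM
compound 3 `Cc1ccccc1-n1nc(C)c2c1NC(=O)[C@H](C)S[C@@H]2c1ccc(Oc2cccc(C(=O)O)c2)cc1` — "not active" (no number reported)

The series is read in an assay on isolated protein for agonist activity at Bile acid receptor (Homo sapiens), read by AlphaScreen, with a stated time of 30 min; a lower number here means that less compound is needed, a higher number that more compound is needed for the effect. Compound 1 gives 990 nM and compound 2 gives 3500 nM; the one step resolved among these, a 3.5-fold higher number from compound 1 to compound 2 (0.55 log units; beyond the scatter), adds one small ether group to the outer aromatic ring. Compound 3 carries an aromatic ring bearing a carboxy group, linked through oxygen, and in this assay compound 3 gives "not active" (no number reported): no number was reported, so compound 3 stands outside the measured range and cannot be ranked against compound 1 or compound 2.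

The next compound to be measured is compound 4 `COc1cccc(Oc2ccc([C@H]3S[C@@H](C)C(=O)Nc4c3c(C)nn4-c3ccccc3C)cc2)c1`. It differs from compound 3 in one place: methoxy in place of carboxy on an aromatic carbon.

Going by the values given here, no measured step describes this exchange. Among the compounds with values here, the only step available, a 3.5-fold higher number from compound 1 to compound 2 (0.55 log units; beyond the scatter), concerns a different change on a different group and is of modest size. What the numbers do show is that an outer aromatic ring with a small ether substituent (compound 2) keeps a measurable number, while the carboxy-bearing ring of compound 3 does not. On that basis the expectation for compound 4 is a return to a measurable number, of roughly the size seen for compound 2 rather than compound 1, with wide uncertainty and a real chance that no number is obtained. For compound 4 in this assay the estimate is 4000 nM, in the range 1000 nM to 20000 nM.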

Compound 4, half-maximal effective concentration: 1700 nM
Compound 4: middle estimate off by 2.4-fold (0.37 log units), on the high side; measured number inside the range.
By their numbers in this assay, from the lowest: compounds 1 and 4 (each within the scatter of the next); then compound 2.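

In this assay the exchange of carboxy for methoxy, on a ring meta to a large group, separates compound 3 at "not active" (no number reported) from compound 4 at 1700 nM as a measurable number, so the oxygen link to the outer ring does not by itself remove the number, and the missing number in this pair goes with the carboxy. Extending the outer ring costs nothing that can be resolved here, as a 1.7-fold higher number from compound 1 to compound 4 (0.23 log units; within the scatter) leaves compound 1 and compound 4 inseparable, whereas a 2.1-fold lower number from compound 2 to compound 4 (0.31 log units; beyond the scatter) shows that 3-methoxyphenoxy and 3-ethoxyphenyl can be told apart, though only just. No measurement at hand explains either the missing number or these modest steps.

On these data alone, that last step changes the link and the ether together, so the share of each stays open, and a 3-ethoxyphenoxy or 3-methoxyphenyl group would be needed to divide it. Also open, as far as these compounds go, is whether the missing number is particular to carboxy or extends to a primary amide, an amine or a hydroxy group at the same place on the ring.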